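A few compounds are considered here, and "the series" means these few. Any claim that something is new, unique, unknown or untested is made for them only; others in the source may bear on it.

Measured compounds:

Compound 1, `Fc1ccc(C2=CC3CNCC(C2)C3)cn1`, gives 136%.
Compound 2, `CN1CC2C=C(c3ccc(F)nc3)CC(C2)C1`, gives 9.4%.
Compound 3, `CC(C)Oc1cncc(C2=CC3CNCC(C2)C3)c1`, gives 54%.

All three were tested in an in vitro functional assay on SH-EP1 cells for agonist activity at Neuronal acetylcholine receptor; alpha4/beta2 (Homo sapiens), read by FLIPR and calcium flux; on this read-out higher numbers stand for larger maximal responses and lower numbers for smaller maximal responses. Compound 1 and compound 2 share a core and differ only by methyl in place of hydrogen on an amine nitrogen in a ring. That single change made a step of a number 126.6 percentage points lower from compound 1 to compound 2 (beyond the scatter), so adding the methyl group to the ring nitrogen almost wiped out the maximal response. Compound 3 carries a different core; how the core of compound 3 and the core of compound 1 differ is not broken down here. In this assay compound 3 sits between the other two, clearly below compound 1 and clearly above compound 2.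

Compound 4, `CC(C)Oc1cncc(C2=CC3CC(C2)CN(C)C3)c1`, has not yet been measured. It differs from compound 3 by methyl in place of hydrogen on an amine nitrogen in a ring. The place of this change is described in the same words as the change from compound 1 to compound 2, so it is the same kind of change on a different core. For the measured compounds named here, since the only measured example of this change, from compound 1 to compound 2, cut the response by a number 126.6 percentage points lower from compound 1 to compound 2 (beyond the scatter), a drop of similar character is expected from compound 3, though it cannot be larger than the response of compound 3 itself. The expected step from compound 3 to compound 4 is therefore a number 48 percentage points lower from compound 3 to compound 4 (beyond the scatter). For compound 4 the estimated value in this assay is 6%, with a range from 0% to 22%.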

Compound 4, largest response reached (reported as percent of maximum), in percent of the reference or control that the assay uses: 3.3%
The estimate for compound 4 lay 2.7 percentage points above the measured number; low and high end bracket the measured number.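

Methyl in place of hydrogen on an amine nitrogen in a ring lowers the maximal response on both cores in this assay, and the new step is a number 50.7 percentage points lower from compound 3 to compound 4 (beyond the scatter), which counts as large. The direction of the change therefore carried over from one core to the other, but its size did not, so a step measured on one core cannot simply be added to another: the same change on two cores in this assay, a number 126.6 percentage points lower (beyond the scatter) from compound 1 to compound 2 and a number 50.7 percentage points lower (beyond the scatter) from compound 3 to compound 4, 75.9 percentage points apart, beyond the scatter of two such steps. For the compounds shown here, with only two pairs, this does not show that the fall would recur on a third core, and it does not explain why the two steps differ in size.

From the compounds shown here alone, whether an ethyl group or a longer chain on that same ring nitrogen would also lower the response, and by how much, stays open, as does the outcome with an acetyl group there, which would turn the amine into an amide. The compounds shown also leave open how the methyl change behaves on any read-out other than the largest response reached, such as the concentration needed to reach that response.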